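Fluoro for methoxy on the pendant ring, two cores

The compounds below may be only part of what the source reports. "The series", "measured", "known", "first", "only" and "open" are said of these compounds alone.

Compound 1 `COc1ccc(OC)c(/C=C/C(=O)C(=Cc2ccc(O)c(OC)c2)C(=O)/C=C/c2cc(OC)ccc2OC)c1` and compound 2 `COc1ccc(OC)c(/C=C/C(=O)C(=Cc2ccc(O)c(F)c2)C(=O)/C=C/c2cc(OC)ccc2OC)c1` share one core; compound 3 `COc1cc(OC)c(/C=C/C(=O)C(=Cc2ccc(O)c(OC)c2)C(=O)/C=C/c2c(OC)cc(OC)cc2OC)c(OC)c1` and compound 4 `COc1cc(OC)c(/C=C/C(=O)C(=Cc2ccc(O)c(F)c2)C(=O)/C=C/c2c(OC)cc(OC)cc2OC)c(OC)c1` share another. How the two cores differ is not broken down here. In a functional assay on SW480 cells (Homo sapiens) for antiproliferative activity, read by sulforhodamine B assay, with a stated time of 48 h (a lower number here means a stronger inhibitor, a higher number a weaker inhibitor), compound 1 gives 410 nM, compound 2 gives 510 nM and compound 3 gives 1490 nM. Compound 3 stands furthest from compound 1 and nearest to compound 2; both gaps are beyond the scatter.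

The change fluoro in place of methoxy on an aromatic carbon gave a 1.2-fold higher number from compound 1 to compound 2 (0.09 log units; within the scatter). The same change, (fluoro in place of methoxy on an aromatic carbon), leads from compound 3 to compound 4; the surroundings of the place are the same in both pairs, so this is the same change on a different core. Compound 4 is not yet measured in this assay. The expected step from compound 3 to compound 4 in this assay is a 1.2-fold higher number from compound 3 to compound 4 (0.07 log units; within the scatter), a step of about the size seen before. This expectation rests on the earlier step, a 1.2-fold higher number from compound 1 to compound 2 (0.09 log units; within the scatter), which stayed within the scatter. Compound 4 is therefore estimated at 1750 nM, with a likely range from 900 nM to 3400 nM; a single core change cannot be checked against the other pair, so the range is kept wide.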

Compound 4, half-maximal inhibitory concentration: 1950 nM
Beside the measured number, compound 4's estimate is 1.1-fold (0.05 log units) below it, within the range that was stated.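

In this assay, fluoro in place of methoxy on the pendant ring again gives a small step, with a 1.3-fold higher number from compound 3 to compound 4 (0.12 log units; within the scatter). Set beside the earlier pair, the change carries from one core to the other with no difference that can be told apart: the same change on two cores in this assay, a 1.2-fold higher number (0.09 log units; within the scatter) from compound 1 to compound 2 and a 1.3-fold higher number (0.12 log units; within the scatter) from compound 3 to compound 4, 1.1-fold (0.02 log units) apart, within the scatter of two such steps. This shows that the step stays within the scatter on these two cores in this one assay; it does not show that the step would stay so small on a further core, and a step of this size gives no order between compound 3 and compound 4.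

The compounds shown place only methoxy or fluoro on this aromatic carbon, always ortho to a hydroxy group, so the outcome with an amine, a carboxylic acid or a longer chain there remains open. Also open, on these data alone, is whether the step would stay this small with that hydroxy group replaced by an amine.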